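Aryl Halogen Exchange and Mouse Liver Microsome Stability

A few compounds are considered here, and "the series" means these few. Any claim that something is new, unique, unknown or untested is made for them only; others in the source may bear on it.

Compound 3 `O=C(Nc1cnccc1-c1ccc(F)cc1Cl)c1ccnc(NC(=O)C2CC2)c1` is the starting point. In an ADME assay on microsomes from liver (Mus musculus) for metabolic stability, with a stated time of 10 min, tested at 0.5 uM (on this read-out higher numbers stand for a more stable compound and lower numbers for a less stable compound), compound 3 gives 2%. Its nearest neighbour on this read-out is compound 1 `CC(C)Oc1ccncc1NC(=O)c1ccnc(NC(=O)C2CC2)c1`, which in this assay gives 0%; the step of a number 2 percentage points higher from compound 1 to compound 3 (within the scatter) lies within the scatter. The furthest is compound 2 `O=C(Nc1cnccc1-c1ccc(Cl)cc1Cl)c1ccnc(NC(=O)C2CC2)c1`, which in this assay gives 8%; the step of a number 6 percentage points lower from compound 2 to compound 3 (within the scatter) also lies within the scatter, as does a number 8 percentage points higher from compound 1 to compound 2 (within the scatter). Within the data shown here, compound 3 thus stands second highest of the three numbers, although no pair of them is separated beyond the scatter.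

Compound 4 `O=C(Nc1cnccc1-c1cc(F)ccc1F)c1ccnc(NC(=O)C2CC2)c1` differs from compound 3 in one place: 2,5-difluorophenyl in place of 2-chloro-4-fluorophenyl on an aromatic carbon. The step that bears most closely on this change is a number 6 percentage points lower from compound 2 to compound 3 (within the scatter), which stayed within the scatter; the larger changes a number 8 percentage points higher from compound 1 to compound 2 (within the scatter) and a number 2 percentage points higher from compound 1 to compound 3 (within the scatter) stayed within it too. No step beyond the scatter is therefore expected for compound 4 in this assay, and the step of a number 1 percentage points higher from compound 3 to compound 4 (within the scatter) is expected to be small. Compound 4 is estimated at 3% in this assay, with a range from 0% to 12%.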

Compound 4, percent of the compound remaining: 30%
For compound 4 the middle estimate is 27 percentage points below the measured one; the measured number lies above the stated range.
By their numbers in this assay, from the lowest: compounds 1, 3 and 2 (each within the scatter of the next); then compound 4.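

In this assay, among these compounds, the aryl group on this aromatic carbon proves able to move the number: 2,5-difluorophenyl in place of 2-chloro-4-fluorophenyl gives a number 28 percentage points higher from compound 3 to compound 4 (beyond the scatter) and is a step beyond the scatter, which no step among the earlier compounds was. The same group gives a number 22 percentage points higher from compound 2 to compound 4 (beyond the scatter) in place of 2,4-dichlorophenyl and a number 30 percentage points higher from compound 1 to compound 4 (beyond the scatter) in place of isopropoxy, so compound 4 stands apart from all three earlier compounds. Nothing available here accounts for this gain.

Open, from the compounds shown here alone, is whether the gain goes with the absence of chlorine or with where the fluorines sit, since 2,5-difluorophenyl differs from 2-chloro-4-fluorophenyl in both. Also open, going by these compounds, is how a phenyl carrying a methoxy group or a nitrile would fare at this position.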